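The source may report more compounds than this note shows. Statements on the series, on what has been measured and on what is new or still open speak of the compounds shown alone.

Working notes on the series. Two compounds have numbers in a toxicity assay on HepG2 cells (Homo sapiens) for cytotoxicity, read by MTT assay, with a stated time of 24 h (on this read-out higher numbers stand for lower toxicity in this test and lower numbers for higher toxicity in this test), so far. Compound 2 `Brc1ccc(Nc2nc3ccccc3nc2Nc2ccc(Br)cc2)cc1` gives 7120 nM in this assay. Compound 1 `O=[N+]([O-])c1ccc2nc(Nc3ccc(F)c(C(F)(F)F)c3)c(Nc3ccc(F)c(C(F)(F)F)c3)nc2c1`, which carries a nitro group on its core and fluoro and trifluoromethyl groups on both anilines, gives 7750 nM in this assay; the two numbers lie within the usual scatter of each other, so neither compound can be set apart from the other on this read-out.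

Compound 3 `O=[N+]([O-])c1ccc2nc(Nc3ccc(Br)cc3)c(Nc3ccc(Br)cc3)nc2c1` is the next compound to be measured in this assay. It differs from compound 2 in one place: nitro in place of hydrogen on an aromatic carbon. Within the data shown here, no pair of measured compounds shows a single-point change of this kind, so no measured step can be carried over. What the data do offer is that compound 1, which also bears a nitro group on the core, gives 7750 nM, a number close to that of compound 2; this suggests that adding the nitro group need not move the number far. The step from compound 2 to compound 3 is therefore expected to be small, a 1.0-fold lower number from compound 2 to compound 3 (0.01 log units; within the scatter), with no clear direction beyond the scatter. For compound 3 the expected value in this assay is 7000 nM, with a likely range from 3500 nM to 14000 nM.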

Compound 3, half-maximal cytotoxic concentration: 8720 nM
Compound 3: the middle estimate sits 1.2-fold (0.10 log units) below what was measured, within the range that was stated.
By their numbers in this assay, from the lowest: compounds 2, 1 and 3 (each within the scatter of the next).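

Nitro in place of hydrogen on an aromatic carbon of the shared core now has a direct single-point reading in this assay: the step is a 1.2-fold higher number from compound 2 to compound 3 (0.09 log units; within the scatter). Earlier, the effect of this change could only be inferred from compound 1, which differs from compound 2 in more than one place, whereas here the anilines are held constant and only the group at this position changes. At this position, in a six-membered aromatic ring of carbon only, nitro therefore leaves the number within the scatter of that of the parent with hydrogen, and no measurement at hand accounts for this.

The compounds shown leave open whether a different group at this position, such as an amine or a carboxylic acid, would likewise stay within the scatter in this assay. They also leave open whether the nitro step would be of similar size with other anilines, such as those carrying fluoro and trifluoromethyl groups, as this single step covers only the anilines of compound 2 and compound 3.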